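A few compounds are considered here, and "the series" means these few. Any claim that something is new, unique, unknown or untested is made for them only; others in the source may bear on it.

Measured compounds:
compound 1 `CCCNC(=O)c1ccc(Oc2nc(-c3c(C)noc3C)cnc2N)cc1` — 17500 nM
compound 2 `Cc1noc(C)c1-c1cnc(N)c(NCc2ccc(C(=O)Nc3ccc(Cl)cc3)cc2)n1` — > 100000 nM

In a functional assay on LoVo cells (Homo sapiens) for inhibition, read by MTT assay, with a stated time of 72 h (a lower number here means a stronger inhibitor, a higher number a weaker inhibitor), compound 1 gives 17500 nM. Compound 2 is recorded only as a limit of the assay, > 100000 nM, not as a number; it sits at the limit of > 100000 nM in this assay, at which 1 of the 2 values shown sits. Compound 3 `Cn1cc(-c2cnc(N)c(NCc3ccc(C(=O)Nc4ccc(Cl)cc4)cc3)n2)cn1` is not yet measured. It differs from compound 2 by 1-methyl-1H-pyrazol-4-yl in place of 3,5-dimethyl-1,2-oxazol-4-yl on an aromatic carbon. Among the measured compounds shown here, no step between two measured compounds is available, so the size of this change in this assay cannot be read from the data. No movement beyond the scatter is expected, and the result is more likely to remain a limit than a number. The expected step is an at least 1.1-fold lower number from compound 2 to compound 3 (0.04 log units; that floor lies within the scatter). For compound 3 the estimate is 90000 nM, with a range of 30000 nM to 300000 nM.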

Compound 3, half-maximal inhibitory concentration: 43600 nM
The estimate for compound 3 lay 2.1-fold (0.31 log units) above the measured number; low and high end bracket the measured number.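

On the aromatic carbon para to an amino group, 1-methyl-1H-pyrazol-4-yl in place of 3,5-dimethyl-1,2-oxazol-4-yl gives, in this assay, an at least 2.2-fold lower number from compound 2 to compound 3 (0.36 log units; beyond the scatter). This position therefore responds to the exchange of one five-membered aromatic ring for another, and compound 3 gives a measured number, 43600 nM. Compound 2 is recorded only as a limit, so the step has a floor and no known full size: the limit of > 100000 nM in this assay, at which 1 of the 3 values shown sits.

Open, going by these compounds, is whether an amine or a carboxylic acid on this carbon would lower the number further. Also open, on these data alone, is what 1-methyl-1H-pyrazol-4-yl does on the core of compound 1.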